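Fluoro on the benzyl arm: compound 3 to compound 4

The compounds below may be only part of what the source reports. "The series", "measured", "known", "first", "only" and "open" are said of these compounds alone.

Of the compounds shown here, three of a shared core have been measured in a functional assay on the whole organism (artery, strain albino) with Rattus norvegicus as the target, with a stated time of 360 min, at a dose of 10 mg/kg by the oral route; on this read-out lower numbers stand for less inhibition and higher numbers for more inhibition at the one dose given (going by the name of the read-out). Compound 1 `CC1=C(C(=O)Nc2ccc(F)cc2)C(c2ccc([N+](=O)[O-])cc2)N=C(SCc2cccc(Cl)c2)N1` gives 21.1%, compound 2 `CC1=C(C(=O)Nc2ccc(Br)cc2)C(c2ccc(Cl)cc2Cl)N=C(SCc2ccccc2)N1` gives 24.2%, and compound 3 `COc1ccc(C2N=C(SCc3ccccc3)NC(C)=C2C(=O)Nc2ccc(Br)cc2)cc1` gives 18.6%. Among the compounds with values here, compound 3 stands within the scatter of both companions; the only single-point step, a number 5.6 percentage points lower from compound 2 to compound 3 (within the scatter), lies within the scatter as well. Compound 4 `COc1ccc(C2N=C(SCc3ccc(F)cc3)NC(C)=C2C(=O)Nc2ccc(Br)cc2)cc1` differs from compound 3 by fluoro in place of hydrogen on an aromatic carbon. Within the data shown here, no measured step touches the benzylsulfanyl arm, so the data say nothing about this change beyond the general flatness seen so far. Compound 4 is therefore expected to show a number 1.4 percentage points higher from compound 3 to compound 4 (within the scatter), no step beyond the scatter. The estimated value for compound 4 in this assay is 20%, between 9% and 32%.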

Compound 4, a percentage reported as inhibition, in the whole organism at one dose (the size of the read-out at that dose, not a potency): 33.5%
The estimate for compound 4 lay 13.5 percentage points below the measured number; measured number outside the range, above it.
By their numbers in this assay, from the lowest: compounds 3, 1, 2 and 4 (each within the scatter of the next, the first and the last beyond it).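

In this assay, within the data shown here, the first step on the shared core to clear the usual scatter comes from the benzyl arm, a number 14.9 percentage points higher from compound 3 to compound 4 (beyond the scatter), on going from benzyl to 4-fluorobenzyl. The one earlier step, on the saturated ring carbon, stayed within the scatter, so this arm is the only place shown where a single change moves the number beyond it. Nothing in the data explains the step.

Going by these compounds, whether chloro, methoxy or a longer chain at this position would do the same remains open. So does whether fluoro gives a like step alongside the 2,4-dichlorophenyl group of compound 2.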